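A chloro substituent tried on the pendant phenyl ring

A few compounds are considered here, and "the series" means these few. Any claim that something is new, unique, unknown or untested is made for them only; others in the source may bear on it.

Three measured compounds share one core that carries a phenyl ring on one side and a substituted aryl group on a double-bonded chain on the other. Compound 1 `COc1cc(/C=C/C(=O)c2cccc(-n3cc(-c4ccccc4)[nH]c3=O)c2)cc(OC)c1OC` gives 4120 nM in a functional assay on HOP-62 cells (Homo sapiens) for inhibition (on this read-out higher numbers stand for weaker inhibition of growth and lower numbers for stronger inhibition of growth), the second highest of the three numbers. Compound 2 `COc1cc(/C=C/C(=O)c2cccc(-n3cc(-c4ccccc4)[nH]c3=O)c2)ccc1O` gives 1480 nM in this assay, a number lower than that of compound 1 by more than the scatter, while compound 3 `O=C(/C=C/c1cccc(O)c1)c1cccc(-n2cc(-c3ccccc3)[nH]c2=O)c1` gives 6930 nM, a number that lies within the scatter of compound 1. Among the compounds with values here, the one single-point step among the measured compounds, a 4.7-fold higher number from compound 2 to compound 3 (0.67 log units; beyond the scatter), comes from 3-hydroxyphenyl in place of 4-hydroxy-3-methoxyphenyl on the double-bonded chain carbon.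

Compound 4 `COc1cc(/C=C/C(=O)c2cccc(-n3cc(-c4ccc(Cl)cc4)[nH]c3=O)c2)cc(OC)c1OC` departs from compound 1 at the other end of the molecule: chloro in place of hydrogen on an aromatic carbon. Within the data shown here, no measured step touches this phenyl ring, so the data give no precedent for how far, or in which direction, a chloro in place of hydrogen there would move the number. The account therefore expects compound 4 to stay close to compound 1, with a step of a 1.0-fold lower number from compound 1 to compound 4 (0.01 log units; within the scatter) that is expected to remain within the scatter. The estimate for compound 4 in this assay is 4000 nM, expected to fall between 1500 nM and 11000 nM.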

Compound 4, concentration for 50% growth inhibition: "not active" (no number reported)
The entry for compound 4 holds no number; the estimate stays without a comparison.
By their numbers in this assay, from the lowest: compound 2; then compounds 1 and 3 (each within the scatter of the next).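

Within the data shown here, compound 4 is entered in this assay as not active, with no number, and no step from compound 1 to compound 4 can be read. The compounds shown leave open how far, and in which direction, chloro in place of hydrogen on this phenyl ring moves the number. No evidence at hand bears on this result.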